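The compounds below may be only part of what the source reports. "The series", "measured", "known", "first", "only" and "open" are said of these compounds alone.

Of the compounds shown here, three have been tested in an assay for inhibition of betaine--homocysteine S-methyltransferase 1 (Homo sapiens), tested at 20 uM (a lower number here means less inhibition, a higher number more inhibition at the concentration tested (going by the name of the read-out)), so far. Compound 1 `NC(CCOCCCCC(=O)O)C(=O)O` gives 9.8% in this assay, compound 2 `C[C@@H](NCCSCCC(N)C(=O)O)C(=O)O` gives 15.5%, and compound 3 `CC(CCSCCC(N)C(=O)O)CC(=O)O` gives 100%. Compound 2 thus stands second highest of the three numbers: its reading and that of compound 1 lie within the usual scatter of one another, while compound 3 sits far above both.

Compound 4 `NC(CCSCCNCCC(=O)O)C(=O)O` differs from compound 2 in one place (2-carboxyethyl in place of 1-carboxyethyl on an amine nitrogen). The two share the same atoms, joined differently. Going by the values given here, nothing measured so far shows how such a change acts in this assay, so a step of about a number 4.5 percentage points higher from compound 2 to compound 4 (within the scatter) is expected, which is none beyond the scatter. For compound 4 a reading of 20% is estimated, expected to fall between 5% and 45%.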

Compound 4, a percentage reported as inhibition, at one concentration (the size of the read-out at that concentration, not a potency): 0%
Compound 4: middle estimate off by 20 percentage points, on the high side, outside the stated range (below it).
By their numbers in this assay, from the lowest: compounds 4, 1 and 2 (each within the scatter of the next, the first and the last beyond it); then compound 3.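

In this assay, 2-carboxyethyl in place of 1-carboxyethyl on an amine nitrogen gives a number 15.5 percentage points lower from compound 2 to compound 4 (beyond the scatter). Going by these compounds alone, this is the first change read at this place, and it shows that the same atoms, joined differently, are enough to move the number. The change also removes the defined stereocentre of 1-carboxyethyl, and nothing available accounts for the step. The compounds shown leave open how a longer chain such as 3-carboxypropyl would read on this amine nitrogen. They also leave open the effect of a primary amide in place of the carboxylic acid.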